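The source may hold more compounds than are shown below. What is called first, only, known or untested is meant among the compounds shown, and "the series" means these compounds.

Measured in a functional assay on A-375 cells (Homo sapiens) for antiproliferative activity, read by MTT assay, with a stated time of 24 h; a lower number here means a stronger inhibitor, a higher number a weaker inhibitor:
- Compound 1 `C=CCOc1ccc2c(=O)c(-c3cc(OC)c(OC)cc3OC)coc2c1`: 4750 nM
- Compound 2 `COc1cc(OC)c(-c2coc3cc(OCc4ccccc4C#N)ccc3c2=O)cc1OC`: 990 nM

Compound 2 holds the lower of these two numbers. Compound 3 `COc1cc(OC)c(-c2coc3cc(OCc4cccc(F)c4)ccc3c2=O)cc1OC` has not yet been measured. It carries 3-fluorophenyl in place of 2-cyanophenyl on a saturated chain carbon bound to an oxygen on an aromatic ring.

Going by the values given here, only one measured step bears on this change: a 4.8-fold lower number from compound 1 to compound 2 (0.68 log units; beyond the scatter). It is modest and occurred at the same place, but it replaced vinyl, so it says little about exchanging one substituted phenyl for another. The expected step is small and within the scatter: a 1.3-fold higher number from compound 2 to compound 3 (0.12 log units; within the scatter).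

For compound 3 the estimated value in this assay is 1300 nM, with an expected range from 450 nM to 3800 nM.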

Compound 3, half-maximal inhibitory concentration: 1300 nM
For compound 3 middle estimate and measured number coincide at the digits printed, within the range that was stated.
By their numbers in this assay, from the lowest: compounds 2 and 3 (each within the scatter of the next); then compound 1.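

In this assay, the 2-cyanophenyl and 3-fluorophenyl groups cannot be told apart, with a 1.3-fold higher number from compound 2 to compound 3 (0.12 log units; within the scatter) as the step between them. A phenyl ring with a different substituent on the same chain carbon still improves on vinyl, with a 3.7-fold lower number from compound 1 to compound 3 (0.56 log units; beyond the scatter) as the step, so this lower number is not tied to the nitrile. Nothing measured here explains this result. On these data alone, it remains open whether a plain phenyl, a basic amine on the ring, or a longer chain between the oxygen and the ring would give a similar number.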